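The source may hold more compounds than are shown below. What is called first, only, known or untested is meant among the compounds shown, and "the series" means these compounds.

Measured compounds:
compound 1 `COc1ccc(F)cc1CNCCCNc1ccnc2cc(Cc3ccc(C#N)cc3)ccc12` — 9.47
compound 2 `COc1ccc(F)cc1CNCCCNc1ccnc2cc(-c3ccccc3)ccc12` — 9.47
compound 3 `COc1ccc(F)cc1CNCCCNc1ccnc2cc(Cc3ccccc3)ccc12` — 9.47

In a physicochemical assay for acid dissociation, compound 3 gives 9.47, level with compound 1 and compound 2 at the digits shown, with no change beyond the scatter to either. Compound 4 `COc1ccc(F)cc1CNCCCNc1ccnc2cc(Oc3ccc(F)cc3)ccc12` differs from compound 3 by 4-fluorophenoxy in place of benzyl on an aromatic carbon. Every measured step concerns this same aromatic carbon: no change at the digits printed from compound 1 to compound 2 (within the scatter), no change at the digits printed from compound 1 to compound 3 (within the scatter) and no change at the digits printed from compound 2 to compound 3 (within the scatter), none of them beyond the scatter. On the strength of these three steps, the change to compound 4 is expected to bring no step beyond the scatter either, so no change at the digits printed from compound 3 to compound 4 (within the scatter) is expected. Compound 4 is therefore estimated at 9.47, within a range from 9.17 to 9.77.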

Compound 4, acid dissociation constant: 9.28
Compound 4: the middle estimate sits 0.19 log units above what was measured; the range from low to high includes it.
By their numbers in this assay, from the lowest: compounds 4, 1, 2 and 3 (each within the scatter of the next).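

With 4-fluorophenoxy on this aromatic carbon, this assay gives a number 0.19 log units lower from compound 3 to compound 4 (within the scatter) and a number 0.19 log units lower from compound 2 to compound 4 (within the scatter) and a number 0.19 log units lower from compound 1 to compound 4 (within the scatter) for the same change, so none of the three steps leaves the scatter. For the compounds shown here, the position has now carried phenyl, benzyl, 4-cyanobenzyl and a group joined through oxygen, and across these four compounds no step goes beyond the scatter. On these data alone, whether an amine or a carboxylic acid on this same carbon would bring a step beyond the scatter stays open. No evidence on the cause accompanies these readings.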